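Swapping an Aromatic Ring for a Dienyl Chain

A few compounds are considered here, and "the series" means these few. Any claim that something is new, unique, unknown or untested is made for them only; others in the source may bear on it.

Three measured compounds share a long-chain amide core and differ only in the group on the carbonyl carbon of the second amide. In a functional assay on A-431 cells (Homo sapiens) for cytotoxicity, read by MTT assay, with a stated time of 48 h (a higher number here means a weaker inhibitor, a lower number a stronger inhibitor), compound 1 `CCCCCCCCCCCCCCCCCCNC(=O)[C@@H](NC(=O)c1ccccc1)[C@@H](C)O` gives 113000 nM, compound 2 `CCCCCCCCCCCCCCCCCCNC(=O)[C@@H](NC(=O)c1cc2ccccc2o1)[C@@H](C)O` gives 78800 nM, and compound 3 `CCCCCCCCCCCCCCCCCCNC(=O)[C@@H](NC(=O)c1nccc2ccccc12)[C@@H](C)O` gives 44100 nM, the lowest of the three numbers, with a 2.6-fold lower number from compound 1 to compound 3 (0.41 log units; beyond the scatter) beyond the scatter and a 1.8-fold lower number from compound 2 to compound 3 (0.25 log units; within the scatter) within it; a 1.4-fold lower number from compound 1 to compound 2 (0.16 log units; within the scatter) is also small. Compound 4 `C/C=C/C=C/C(=O)N[C@H](C(=O)NCCCCCCCCCCCCCCCCCC)[C@@H](C)O` brings a different kind of change: penta-1,3-dien-1-yl in place of isoquinolin-1-yl on a carbonyl carbon. Among the compounds with values here, no measured step removes the ring system entirely, so the measured steps bear on it only loosely; a modest rise is expected because a 2.6-fold lower number from compound 1 to compound 3 (0.41 log units; beyond the scatter) came with a larger ring system entering. Compound 4 is therefore estimated at 90000 nM, between 35000 nM and 250000 nM. That amounts to an expected step of a 2.0-fold higher number from compound 3 to compound 4 (0.31 log units; beyond the scatter).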

Compound 4, half-maximal inhibitory concentration: 187000 nM
Compound 4: the middle estimate sits 2.1-fold (0.32 log units) below what was measured; the range from low to high includes it.
By their numbers in this assay, from the lowest: compounds 3, 2, 1 and 4 (each within the scatter of the next, the first and the last beyond it).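

In this assay, penta-1,3-dien-1-yl gives a 4.2-fold higher number from compound 3 to compound 4 (0.63 log units; beyond the scatter) and a 2.4-fold higher number from compound 2 to compound 4 (0.38 log units; beyond the scatter) and both lie beyond the scatter, while a 1.7-fold higher number from compound 1 to compound 4 (0.22 log units; within the scatter) stays within it. So on this carbonyl carbon, the ringless chain cannot be told apart from phenyl, while it stands clear of isoquinolin-1-yl and 1-benzofuran-2-yl. No evidence is available to explain these differences. The compounds shown leave open whether the double bonds matter, which a saturated pentyl chain in this place would test, and whether a pyridin-2-yl group would match isoquinolin-1-yl.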